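Sulfonyl aryl exchange in the benzylamide sulfonamide series

The source may hold more compounds than are shown below. What is called first, only, known or untested is meant among the compounds shown, and "the series" means these compounds.

Three compounds have numbers in an assay on MDA-MB-231 cells for displacement of a labelled ligand from C-X-C chemokine receptor type 4 (Homo sapiens), read by fluorescence and microscopy, with stated times of 10 min and 30 min; a higher number here means that more compound is needed for the effect, a lower number that less compound is needed. Compound 1 `COc1ccccc1C(=O)NCc1ccc(CNS(=O)(=O)c2ccc([N+](=O)[O-])cc2)cc1` gives 100 nM. Compound 2 `Cc1ccccc1C(=O)NCc1ccc(CNS(=O)(=O)c2ccc([N+](=O)[O-])cc2)cc1` gives 100 nM. Compound 3 `O=C(NCc1ccc(CNS(=O)(=O)c2ccc(Cl)cc2)cc1)c1cccnc1` gives 1000 nM. Going by the values given here, the one single-place step measured, no change at the digits printed from compound 1 to compound 2 (within the scatter), concerns methyl in place of methoxy on an aromatic carbon. Compound 2 stands level with compound 1 at the digits shown, the two together the lowest numbers of the three, and compound 3 stands a good deal higher, beyond the scatter.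

Compound 4 `Cc1ccccc1C(=O)NCc1ccc(CNS(=O)(=O)c2cccc3ccccc23)cc1` differs from compound 2 only at the sulfonyl sulfur: naphthalen-1-yl in place of 4-nitrophenyl on a sulfonyl sulfur. Among the compounds with values here, no measured step alters the aryl on the sulfonyl sulfur alone; compound 3 differs from compound 2 in two places and gives no clean reading of this change. Within the data shown here, the only measured step, no change at the digits printed from compound 1 to compound 2 (within the scatter), sits on the other end of the shared core and bears on this change merely as a sign that the series tolerates small aryl edits. Compound 4 is therefore expected near compound 2, with a wide range and no step beyond the scatter, a 1.5-fold higher number from compound 2 to compound 4 (0.18 log units; within the scatter). The estimate for compound 4 in this assay is 150 nM, between 40 nM and 600 nM.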

Compound 4, effective concentration (reported as EC, without a stated level of effect): 100 nM
Estimate against measurement, compound 4: 1.5-fold (0.18 log units) above; the measured number falls inside the stated range.
By their numbers in this assay, from the lowest: compounds 1, 2 and 4 (each within the scatter of the next); then compound 3.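

Working from this assay, the sulfonyl sulfur now has its first clean reading: naphthalen-1-yl in place of 4-nitrophenyl gives no change at the digits printed from compound 2 to compound 4 (within the scatter). The nitro group and its hydrogen-bond acceptors are therefore not required to hold the number in this pair, and a larger carbon-only aryl with two aromatic rings is accepted at this place. No available data explain why the two groups read alike.

Compound 3 differs from compound 2 in two places, so its higher number cannot be assigned to the 4-chlorophenyl group or to the amide end alone. Still open, on these data alone, is how the sulfonyl position responds to an aryl bearing an amine or a carboxylic acid, or to a longer alkyl chain in place of the aryl.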